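The source may report more compounds than this note shows. Statements on the series, on what has been measured and on what is new or still open speak of the compounds shown alone.

Measured compounds in a functional assay on HL60/MX2 cells (Homo sapiens) for antiproliferative activity, read by MTT assay, with a stated time of 48 h; on this read-out lower numbers stand for stronger inhibition and higher numbers for weaker inhibition:
compound 1, `CCN(CC)CCn1c(N)c(-c2nc3ccccc3[nH]2)c2nc(C#N)c(C#N)nc21`, gives 7150 nM
compound 2, `CN(C)CCCn1c(N)c(-c2nc3ccccc3[nH]2)c2nc(C#N)c(C#N)nc21`, gives 2390 nM
compound 3, `CCN(CC)CCCn1c(N)c(-c2nc3ccccc3n2C)c2nc(C#N)c(C#N)nc21`, gives 4470 nM

Compound 1 and compound 2 differ in one place: (dimethylamino)methyl in place of diethylamino on a saturated chain carbon, two bonds along the chain from an aromatic nitrogen. That change gave a 3.0-fold lower number from compound 1 to compound 2 (0.48 log units; beyond the scatter). Compound 3 stands on a different core from compound 1; the difference between the two cores is not broken down here, and the values of compound 3 and compound 1 lie within the scatter of each other, as do those of compound 3 and compound 2.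

Compound 4, `CN(C)CCCCn1c(N)c(-c2nc3ccccc3n2C)c2nc(C#N)c(C#N)nc21`, has not yet been measured in this assay. It differs from compound 3 by the same kind of change: (dimethylamino)methyl in place of diethylamino on a saturated chain carbon, three bonds along the chain from an aromatic nitrogen. The place is not the same word for word, since in compound 1 and compound 2 the change sits on a saturated chain carbon two bonds along the chain from an aromatic nitrogen, whereas here it sits three bonds along.

Because the earlier change gave a 3.0-fold lower number from compound 1 to compound 2 (0.48 log units; beyond the scatter), a step of similar direction is expected, estimated as a 2.5-fold lower number from compound 3 to compound 4 (0.40 log units; beyond the scatter), though the different core and the longer chain make it less certain. Compound 4 is therefore expected to give about 1800 nM in this assay, estimated to lie between 700 nM and 4500 nM.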

Compound 4, half-maximal inhibitory concentration: 2580 nM
For compound 4 the middle estimate is 1.4-fold (0.16 log units) below the measured one, and the stated range covers the measured number.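

In this assay, putting (dimethylamino)methyl in place of diethylamino on the core of compound 3 gave a 1.7-fold lower number from compound 3 to compound 4 (0.24 log units; within the scatter), a step that cannot on its own be told apart from repeat measurement. Set beside the earlier step, the two do not differ by more than the scatter allows: the same change on two cores in this assay, a 3.0-fold lower number (0.48 log units; beyond the scatter) from compound 1 to compound 2 and a 1.7-fold lower number (0.24 log units; within the scatter) from compound 3 to compound 4, 1.7-fold (0.24 log units) apart, within the scatter of two such steps. This shows that the results on the two cores are compatible with one shared step, but it does not show a dependable gain on the second core, and the core and the chain position differ together between the two pairs, so their contributions cannot be separated.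

The compounds shown leave open whether the step would hold with a cyclic amine such as piperidine in place of these open-chain amines. They also leave open how it would behave on a chain longer than 4-(dimethylamino)butyl.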